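Shifting the hydroxyl on a shared core

The source may report more compounds than this note shows. Statements on the series, on what has been measured and on what is new or still open speak of the compounds shown alone.

Compound 1, `Oc1ccccc1-c1cc(-c2cccc(F)c2)cc(-c2ccccc2O)n1`, in a functional assay on T47D cells (Homo sapiens) for inhibition (a higher number here means a weaker inhibitor, a lower number a stronger inhibitor), gives > 50000 nM, a limit of the assay. Compound 2, `Oc1ccc(-c2cc(-c3cccc(F)c3)cc(-c3ccccc3O)n2)cc1`, in this assay gives > 50000 nM, again a limit. Compound 3, `Oc1ccc(-c2cc(-c3ccc(F)cc3)cc(-c3ccccc3O)n2)cc1`, in this assay gives > 50000 nM, also a limit.

Compound 2 therefore stands at a limit and not at a number, and the other two values shown are limits as well, so the three compounds cannot be ordered against each other. The step from compound 1 to compound 2, a step that the two limits leave unreadable from compound 1 to compound 2, and the step from compound 2 to compound 3, a step that the two limits leave unreadable from compound 2 to compound 3, are both unreadable for this reason; the limit of > 50000 nM in this assay, at which 3 of the 3 values shown sit, is the whole of what the three values tell.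

Compound 4, `Oc1ccc(-c2cc(-c3cccc(F)c3)cc(-c3cccc(O)c3)n2)cc1`, differs from compound 2 by 3-hydroxyphenyl in place of 2-hydroxyphenyl on an aromatic carbon. Both measured steps touch the same region of the shared core, yet neither gives a readable size, so they offer no direction for this change. It is estimated that compound 4 will behave like compound 2 and that a number no higher from compound 2 to compound 4 (the limit leaves the size open) is the step expected, with no movement beyond the scatter. Compound 4 is expected to give 50000 nM, with a range from 10000 nM to 200000 nM, most likely again reported only as a limit.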

Compound 4, half-maximal inhibitory concentration: 3510 nM
Beside the measured number, compound 4's estimate is 14-fold (1.15 log units) above it; measured number below the stated range.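

In this assay, replacing 2-hydroxyphenyl with 3-hydroxyphenyl on the aromatic carbon next to the ring nitrogen gives an at least 14-fold lower number from compound 2 to compound 4 (1.15 log units; beyond the scatter). Among these compounds, the group that leaves and the group that enters have the same atoms and the same counts of hydrogen-bond donors and acceptors, so this position responds to where the hydroxyl sits on that phenyl group, something the earlier compounds could not show. Compound 4 is the only compound shown with a number rather than a limit, while compounds 1, 2 and 3 each stay at a limit of the assay: the limit of > 50000 nM in this assay, at which 3 of the 4 values shown sit.

The compounds shown leave open whether 3-hydroxyphenyl at this position has the same effect when the 3-fluorophenyl group of compound 4 gives way to the 4-fluorophenyl group of compound 3, and whether the 4-hydroxyphenyl group is needed for it. They also leave open whether the hydroxyl itself matters, a question that a methoxy group, an amine or a carboxylic acid at the same place on that phenyl group would address.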